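Three Compounds Measured, a Fourth Awaiting Its Number

The source may hold more compounds than are shown below. What is called first, only, known or untested is meant among the compounds shown, and "the series" means these compounds.

Three compounds share one core and differ only in the aryl group at the end of the double-bonded chain. Compound 1 `COc1cccc(/C=C/C(=O)Nc2cc(C(=O)c3cc(OC)c(OC)c(OC)c3)cc(OC)c2OC)c1` gives 12500 nM in a functional assay on DU-145 cells (Homo sapiens) for cytotoxicity, read by MTT assay, with a stated time of 72 h; a higher number here means a weaker inhibitor, a lower number a stronger inhibitor. Compound 2 `COc1ccc(/C=C/C(=O)Nc2cc(C(=O)c3cc(OC)c(OC)c(OC)c3)cc(OC)c2OC)cc1N` gives 12700 nM in this assay, and compound 3 `C#CCOc1cccc(/C=C/C(=O)Nc2cc(C(=O)c3cc(OC)c(OC)c(OC)c3)cc(OC)c2OC)c1` gives 13500 nM. Compound 3 carries the highest of the three numbers, but its neighbours lie very close: the step of a 1.1-fold higher number from compound 1 to compound 3 (0.03 log units; within the scatter) and the step of a 1.1-fold higher number from compound 2 to compound 3 (0.03 log units; within the scatter) are both within the scatter, as is a 1.0-fold higher number from compound 1 to compound 2 (0.01 log units; within the scatter). Among the measured compounds shown here, nothing done at this position so far has moved the number beyond the usual spread of the measurement.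

Compound 4 `COc1cc(C(=O)c2cc(OC)c(OC)c(OC)c2)cc(NC(=O)/C=C/c2ccc(F)cc2)c1OC` has not yet been measured in this assay. It differs from compound 3 by 4-fluorophenyl in place of 3-(propargyloxy)phenyl on a double-bonded chain carbon bound to a double-bonded chain carbon. For the measured compounds named here, the steps that bear on this change, all at the same place on the chain, were a 1.0-fold higher number from compound 1 to compound 2 (0.01 log units; within the scatter), a 1.1-fold higher number from compound 2 to compound 3 (0.03 log units; within the scatter) and a 1.1-fold higher number from compound 1 to compound 3 (0.03 log units; within the scatter), each within the scatter. The step of a 1.0-fold lower number from compound 3 to compound 4 (0.02 log units; within the scatter) is therefore expected to be no larger than the scatter, in either direction. Compound 4 is estimated at 13000 nM, within a range from 6500 nM to 26000 nM.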

Compound 4, half-maximal inhibitory concentration: 6700 nM
Compound 4: middle estimate off by 1.9-fold (0.29 log units), on the high side; the range from low to high includes it.
By their numbers in this assay, from the lowest: compounds 4, 1, 2 and 3 (each within the scatter of the next).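

With 4-fluorophenyl at this place on the chain, the steps in this assay are the largest seen there so far, and all three remain within the scatter: a 2.0-fold lower number from compound 3 to compound 4 (0.30 log units; within the scatter), a 1.9-fold lower number from compound 2 to compound 4 (0.28 log units; within the scatter) and a 1.9-fold lower number from compound 1 to compound 4 (0.27 log units; within the scatter). This extends the earlier picture to a group of a different kind. 4-fluorophenyl brings fewer heavy atoms than 3-(propargyloxy)phenyl, and it carries fluorine where the other three compounds carry oxygen-linked groups, yet compound 4 still cannot be separated from compounds 1, 2 and 3 by these numbers. Nothing available accounts for the size of these steps, so they are recorded here without an explanation.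

The four compounds leave open whether any group at this place can produce a step beyond the scatter, for example a phenyl bearing a carboxylic acid, a dimethylamino group or a trifluoromethyl group, or a longer chain between the aryl ring and the amide carbonyl. They also leave open whether the fluorine contributes to the step at all, a question that the plain phenyl group or 3-fluorophenyl at the same place would address.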